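Oxazole ketone series: exchanging the pyridyl arm for a thioester

The source may report more compounds than this note shows. Statements on the series, on what has been measured and on what is new or still open speak of the compounds shown alone.

Measured compounds:
compound 1 `O=C(CCCCCCc1ccccc1)c1ncc(-c2ccc(CCl)cn2)o1`: 24.6 nM
compound 2 `N#C/C=C/c1ccc(-c2cnc(C(=O)CCCCCCc3ccccc3)o2)nc1`: 2.7 nM
compound 3 `C[S+]([O-])/C=C/c1ccc(-c2cnc(C(=O)CCCCCCc3ccccc3)o2)nc1`: 0.9 nM

Three compounds sharing one core were examined in an assay for inhibition of Fatty-acid amide hydrolase 1 (Rattus norvegicus), using a Dixon plot, with a stated time of 6 h; a higher number here means a weaker inhibitor, a lower number a stronger inhibitor. Compound 1 gives the highest number of the three; compound 2 sits nearest at a 9.1-fold lower number from compound 1 to compound 2 (0.96 log units; beyond the scatter), and compound 3 furthest at a 27-fold lower number from compound 1 to compound 3 (1.44 log units; beyond the scatter). Between the two stronger compounds the step is a 3.0-fold lower number from compound 2 to compound 3 (0.48 log units; beyond the scatter).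

Compound 4 `CSC(=O)CCCCc1cnc(C(=O)CCCCCCc2ccccc2)o1` has not yet been measured. It differs from compound 1 by a group of 8 heavy atoms (6 carbon, 1 oxygen, 1 sulfur; no ring) in place of a group of 8 heavy atoms (6 carbon, 1 nitrogen, 1 chlorine; one six-membered aromatic ring with 1 hetero atom), on an aromatic carbon. Among the measured compounds shown here, none of the measured steps maps onto this change: each of them kept the six-membered aromatic ring and altered only the group it carries, whereas here the ring itself is gone and an open chain ending in a thioester takes its place. The earlier steps shown here show only that this position tolerates sizeable moves in the number, both modest and large, all toward stronger inhibition when the ring stays. For the measured compounds named here, with no comparable step to lean on, a weaker result than compound 1 is expected, with wide uncertainty. Compound 4 is expected to give 120 nM, within 20 nM to 700 nM. The expected step is a 4.9-fold higher number from compound 1 to compound 4 (0.69 log units; beyond the scatter).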

Compound 4, inhibition constant: 1.5 nM
Compound 4: middle estimate off by 80-fold (1.90 log units), on the high side, outside the stated range (below it).
By their numbers in this assay, from the lowest: compounds 3, 4 and 2 (each within the scatter of the next, the first and the last beyond it); then compound 1.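

The change gives a 16-fold lower number from compound 1 to compound 4 (1.21 log units; beyond the scatter), so at this position, on an aromatic carbon next to the ring oxygen, the six-membered aromatic ring with 1 hetero atom is not required for a low number in this assay. The earlier compounds shown here all kept that ring and varied only the group it carries, whereas compound 4 shows that an open chain ending in a thioester, with no ring at all, can take its place and still lower the number relative to compound 1. No measurement shown here accounts for this step.

The compounds shown leave open whether the thioester itself matters, since an oxygen ester, an amide or a carboxylic acid at the chain end does not appear among them. They also leave open how a shorter or longer chain would behave.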